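Methoxy pattern on the aromatic ring and cytotoxicity

A few compounds are considered here, and "the series" means these few. Any claim that something is new, unique, unknown or untested is made for them only; others in the source may bear on it.

Compound 1 `COc1ccc(-c2cc(/C=C/C(=O)c3ccc(N)cc3)[nH]n2)cc1` and compound 2 `COc1cc(-c2cc(/C=C/C(=O)c3ccc(N)cc3)[nH]n2)cc(OC)c1OC` share one core and differ only in the methoxy pattern on one six-membered aromatic ring of carbon only. In a functional assay on HCT-15 cells (Homo sapiens) for cytotoxicity, read by sulforhodamine B assay, with a stated time of 48 h, tested at 10 uM (on this read-out lower numbers stand for a stronger effect and higher numbers for a weaker effect at the one concentration tested), compound 1 gives -40% and compound 2 gives -12%. Compound 2 stands highest of the two numbers, its gap to compound 1 lying beyond the scatter. Compound 3 `COc1ccc(-c2cc(/C=C/C(=O)c3ccc(N)cc3)[nH]n2)cc1OC` is not yet measured; against compound 2 it shows (hydrogen in place of methoxy on an aromatic carbon). Because compound 1 gives -40% with fewer methoxy groups, a downward step in this assay, possibly beyond the scatter, is expected. The estimated step is a number 14 percentage points lower from compound 2 to compound 3 (beyond the scatter). For compound 3 the expected value is -26%, within -48% to -6%.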

Compound 3, a percentage reported as activity, at one concentration (the size of the read-out at that concentration, not a potency): -27%
Compound 3: middle estimate off by 1 percentage points, on the high side, and the stated range covers the measured number.
By their numbers in this assay, from the lowest: compound 1; then compound 3; then compound 2.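

In this assay, the gap between the two earlier compounds now divides into single changes: hydrogen in place of methoxy gives a number 15 percentage points lower from compound 2 to compound 3 (beyond the scatter), and methoxy in place of hydrogen gives a number 13 percentage points higher from compound 1 to compound 3 (beyond the scatter). Within the data shown here, both steps lie beyond the scatter, and across these three compounds the number rises with each added methoxy, with no compound going against this. Nothing available gives a reason for these steps.

Open, on these data alone, is whether a hydroxyl or an amine at this position would follow the same direction as methoxy. Also open, as far as these compounds go, is whether the step depends on where on the ring the methoxy sits.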